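The compounds below may be only part of what the source reports. "The series", "measured", "known", "first", "only" and "open" are said of these compounds alone.

Working notes on the series. Compound 1 `Cc1nnc(SCc2ccccc2)n1N1C(=O)c2ccccc2C1=O` carries a benzylsulfanyl group on the shared core. In a functional assay on PC-3M cells (Homo sapiens) for cytotoxicity, read by MTT assay, with a stated time of 48 h (a higher number here means a weaker inhibitor, a lower number a stronger inhibitor), compound 1 gives > 200000 nM, which is a limit of the assay and not a number. Compound 2 `Cc1ccc(C(=O)CSc2nnc(C)n2N2C(=O)c3ccccc3C2=O)cc1` has a (4-methylphenyl)carbonyl in place of phenyl on a saturated chain carbon bound to a sulfur. In this assay compound 2 gives > 200000 nM, again a limit of the assay. The step that the two limits leave unreadable from compound 1 to compound 2 therefore gives no size. The whole of what the measurements show is the limit of > 200000 nM in this assay, at which 2 of the 2 values shown sit, so compound 1 stands nowhere more precise than at that limit.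

Compound 3 `C#CCSc1nnc(C)n1N1C(=O)c2ccccc2C1=O` differs from compound 1 by ethynyl in place of phenyl on a saturated chain carbon bound to a sulfur. Within the data shown here, the one measured step, the unreadable one between the two limits, is the only step that bears on this change, and it sets no direction and no size. The step that the limit leaves unreadable from compound 1 to compound 3 is therefore expected to be none beyond the scatter, with compound 3 most likely reported as a limit again. Compound 3 is estimated at 250000 nM in this assay, within a range from 100000 nM to 600000 nM.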

Compound 3, half-maximal inhibitory concentration: > 200000 nM
Compound 3: a limit, no number; the forecaster's own chance of this, stated with the estimate: 85%; the middle value is on the limit's open side.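

No step among compound 1, compound 2 and compound 3 can be read in this assay; what stands is a limit of the assay and not a number: the limit of > 200000 nM in this assay, at which 3 of the 3 values shown sit.

The compounds shown leave open whether any group on the saturated chain carbon bound to a sulfur brings a measurable value in this assay.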